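A few compounds are considered here, and "the series" means these few. Any claim that something is new, unique, unknown or untested is made for them only; others in the source may bear on it.

Compound 1 `N#C/C(=C\c1ccc(O)c(O)c1)C(=O)OC1CCCCC1` gives 55.3% in a functional assay on the whole organism (strain CD1) for inhibition, with Mus musculus as the target, with stated times of 15 min and 20 min, at a dose of 10 mg/kg by the subcutaneous route; a lower number here means less inhibition, a higher number more inhibition at the dose given (going by the name of the read-out). Compound 2 `N#C/C(=C\c1ccoc1)C(=O)O` gives 30.7%. Compound 3 `CCOC(=O)/C(C#N)=C/c1ccoc1` gives 55.9%.

Compound 3 stands at the top of these three numbers; its gap from compound 1 is within the scatter, while compound 2 lies beyond it. Compound 4 `CC(C)(C)OC(=O)/C(C#N)=C/c1ccoc1` differs from compound 3 by tert-butyl in place of ethyl on an oxygen next to a carbonyl group. For the measured compounds named here, the only measured step on an oxygen next to a carbonyl group is a number 25.2 percentage points higher from compound 2 to compound 3 (beyond the scatter), where ethyl replaced hydrogen; there is no measured step from ethyl to a larger alkyl on that oxygen. The expected step of a number 1.9 percentage points lower from compound 3 to compound 4 (within the scatter) is therefore none beyond the scatter. Compound 4 is estimated at 54%, expected between 35% and 72%.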

Compound 4, a percentage reported as inhibition, in the whole organism at one dose (the size of the read-out at that dose, not a potency): 81.8%
Estimate against measurement, compound 4: 27.8 percentage points below, and the stated range ends below it.
By their numbers in this assay, from the lowest: compound 2; then compounds 1 and 3 (each within the scatter of the next); then compound 4.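

On an oxygen next to a carbonyl group, the choice of alkyl group still matters once ethyl is in place: in this assay, tert-butyl in place of ethyl gives a number 25.9 percentage points higher from compound 3 to compound 4 (beyond the scatter). Taken from hydrogen, the same position gives a number 51.1 percentage points higher from compound 2 to compound 4 (beyond the scatter), so the read-out rises at each step from hydrogen to ethyl to tert-butyl in these three compounds. Nothing available explains this rise. Open, as far as these compounds go, is how a longer chain such as n-butyl, or a benzyl group, would read on that oxygen. Also open, from the compounds shown here alone, is whether tert-butyl would give a similar rise on the core of compound 1.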